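The source may report more compounds than this note shows. Statements on the series, on what has been measured and on what is new or still open speak of the compounds shown alone.

Measured compounds:
- compound 1 `CN(C[C@H]1Cc2c(cccc2N2CCN(C3COC3)CC2)CN1)[C@H]1CCCc2cccnc21`: 381 nM
- compound 2 `CCN(C[C@H]1Cc2c(cccc2N2CCNCC2)CN1)[C@H]1CCCc2cccnc21`: 14.8 nM
- compound 3 `CC(C)N(C[C@H]1Cc2c(cccc2N2CCNCC2)CN1)[C@H]1CCCc2cccnc21`: 364 nM

In a functional assay on CCRF-CEM cells for antagonist activity at C-X-C chemokine receptor type 4 (Homo sapiens), read by calcium flux, with stated times of 25 min and 90 s (on this read-out lower numbers stand for stronger inhibition and higher numbers for weaker inhibition), compound 1 gives the highest of the three numbers; it sits close to compound 3 and far from compound 2. Among the compounds with values here, the only step between compounds that differ in one place, a 25-fold higher number from compound 2 to compound 3 (1.39 log units; beyond the scatter), concerns the group on the amine nitrogen and not the position changed here. Compound 4 `CN(C[C@H]1Cc2c(cccc2N2C[C@@H]3C[C@H]2CN3)CN1)[C@H]1CCCc2cccnc21` differs from compound 1 by a group of 7 heavy atoms (5 carbon, 2 nitrogen; 2 five-membered non-aromatic rings with 1 hetero atom each) in place of a group of 10 heavy atoms (7 carbon, 2 nitrogen, 1 oxygen; one four-membered non-aromatic ring with 1 hetero atom, one six-membered non-aromatic ring with 2 hetero atoms), on an aromatic carbon. Within the data shown here, no measured pair isolates this change; the sole hint is that compound 2, carrying a free donor at the same place, gives a far lower number than compound 1, though it also differs on the amine. Compound 4 is therefore expected at 120 nM (range 30 nM to 500 nM), a step of a 3.2-fold lower number from compound 1 to compound 4 (0.50 log units; beyond the scatter) whose size is uncertain.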

Compound 4, half-maximal inhibitory concentration: 146 nM
Estimate against measurement, compound 4: 1.2-fold (0.09 log units) below; the range from low to high includes it.
By their numbers in this assay, from the lowest: compound 2; then compound 4; then compounds 3 and 1 (each within the scatter of the next).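

With the rest of the molecule unchanged, putting the group with two five-membered non-aromatic rings in place of 4-(oxetan-3-yl)piperazin-1-yl on this aromatic carbon gives a 2.6-fold lower number from compound 1 to compound 4 (0.42 log units; beyond the scatter) in this assay. Within the data shown here, this is the first direct sign that the number in this assay responds to the group at this position, although the step is modest. Nothing measured here explains the step. The entering group differs in both its rings and its hydrogen-bond donor, so the two remain unseparated. From the compounds shown here alone, how a morpholin-4-yl or an unsubstituted piperazin-1-yl group would read on the core of compound 1 stays open.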